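Sulfonate ester series: urea nitrogen substituent, propyl to cyclopropyl

The compounds below may be only part of what the source reports. "The series", "measured", "known", "first", "only" and "open" are said of these compounds alone.

Compound 2 `CCCNC(=O)Nc1ccc(S(=O)(=O)Oc2ccccc2I)cc1` carries a propylcarbamoyl amino group on the shared core. Going by the values given here, in a functional assay on HT-1080 cells (Homo sapiens) for antiproliferative activity, read by sulforhodamine B assay, with a stated time of 48 h (on this read-out higher numbers stand for weaker inhibition and lower numbers for stronger inhibition), compound 2 gives 700 nM, the lowest of the two numbers so far. Among the compounds with values here, its only neighbour is compound 1 `CC(C)C(=O)Nc1ccc(S(=O)(=O)Oc2ccccc2I)cc1`, which in this assay gives 3300 nM; the step of a 4.7-fold lower number from compound 1 to compound 2 (0.67 log units; beyond the scatter) exchanges an isobutyramide for a propyl urea and is the only measured step in the set. Compound 3 `O=C(Nc1ccc(S(=O)(=O)Oc2ccccc2I)cc1)NC1CC1` differs from compound 2 by cyclopropyl in place of propyl on an amide-type nitrogen. Within the data shown here, no measured step addresses this exchange: the one step on record changes the carbonyl substituent and the presence of the urea nitrogen, not the group on that nitrogen. With nothing to carry over, no step beyond the scatter is expected from compound 2 to compound 3, the expectation being no change at the digits printed from compound 2 to compound 3 (within the scatter). Compound 3 is therefore estimated at 700 nM in this assay, within a range of 250 nM to 2000 nM.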

Compound 3, half-maximal inhibitory concentration: 1300 nM
The estimate for compound 3 lay 1.9-fold (0.27 log units) below the measured number; measured number inside the range.
By their numbers in this assay, from the lowest: compounds 2 and 3 (each within the scatter of the next); then compound 1.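

In this assay, the group on the amide-type nitrogen can change from the open propyl chain to the cyclopropyl ring, with the same count of heavy atoms, without a step beyond the scatter: a 1.9-fold higher number from compound 2 to compound 3 (0.27 log units; within the scatter). The advantage of the urea over the isobutyramide also holds with this second nitrogen substituent, with a 2.5-fold lower number from compound 1 to compound 3 (0.40 log units; beyond the scatter), so both ureas shown, compound 2 and compound 3, give lower numbers than compound 1 and neither goes against this. No supporting data are available to explain either step.

Still open, on these data alone, is how far this tolerance extends on that nitrogen, for example to a longer chain such as butyl or a larger ring such as cyclohexyl. Also open, as far as these compounds go, is the effect of placing an amine or a carboxylic acid on the nitrogen substituent.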